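A few compounds are considered here, and "the series" means these few. Any claim that something is new, unique, unknown or untested is made for them only; others in the source may bear on it.

In an ADME assay on Vero cells (Chlorocebus sabaeus) for cytotoxicity, read by MTT assay, with a stated time of 72 h (on this read-out higher numbers stand for weaker inhibition and lower numbers for stronger inhibition), compound 1 `O=C(Nc1nc(-c2ccccc2)cs1)c1ccc([N+](=O)[O-])o1` gives 41700 nM, compound 2 `O=C(Nc1nc(-c2cccc(Cl)c2)cs1)c1ccc([N+](=O)[O-])o1` gives 43700 nM and compound 3 `O=C(Nc1nc(-c2cccc(Br)c2)cs1)c1ccc([N+](=O)[O-])o1` gives 71000 nM, so compound 1 stands level with both within the scatter. Compound 4 `O=C(Nc1nc(-c2cccc(C(F)(F)F)c2)cs1)c1ccc([N+](=O)[O-])o1` keeps the core of compound 1 and differs from it by trifluoromethyl in place of hydrogen on an aromatic carbon, meta to a large group. The closest measured changes are chloro and bromo in place of hydrogen on an aromatic carbon, a 1.0-fold higher number from compound 1 to compound 2 (0.02 log units; within the scatter) and a 1.7-fold higher number from compound 1 to compound 3 (0.23 log units; within the scatter), both within the scatter. No step beyond the scatter is therefore expected in this assay. The estimated step is a 1.3-fold higher number from compound 1 to compound 4 (0.12 log units; within the scatter). For compound 4 the expected value is 55000 nM, with an estimated range of 28000 nM to 110000 nM.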

Compound 4, half-maximal inhibitory concentration: 23900 nM
The estimate for compound 4 lay 2.3-fold (0.36 log units) above the measured number; the measured number lies below the stated range.
By their numbers in this assay, from the lowest: compounds 4, 1, 2 and 3 (each within the scatter of the next, the first and the last beyond it).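

In this assay, within the data shown here, the one step at this place that passes the scatter is a 3.0-fold lower number from compound 3 to compound 4 (0.47 log units; beyond the scatter), a modest step that replaces bromo with trifluoromethyl. The other two steps stay within the scatter, a 1.7-fold lower number from compound 1 to compound 4 (0.24 log units; within the scatter) and a 1.8-fold lower number from compound 2 to compound 4 (0.26 log units; within the scatter), so trifluoromethyl does not separate from hydrogen or chloro here. Nothing measured here explains the gap between bromo and trifluoromethyl. Going by these compounds, whether an amine, a carboxylic acid or a longer chain at this place would stay within the same narrow band remains open.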